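This account rests on a few compounds, and the source may have more. Where it says the series, first, only, none or still open, it means among the compounds named here.

Measured compounds in an ADME assay on HEL cells (Homo sapiens) for cytotoxicity, with a stated time of 3 days; a lower number here means that less compound is tolerated, a higher number that more compound is tolerated:
compound 1 `CCCCCc1ccc(-c2cc3cn([C@H]4C[C@H](O)[C@@H](CO)O4)c(=O)nc3o2)nc1` gives > 50000 nM, which is a limit of the assay.
compound 2 `CCCCCc1cnc(-c2cc3cn([C@H]4C[C@H](O)[C@@H](CO)O4)c(=O)nc3o2)nc1` gives > 50000 nM, which is a limit of the assay.
compound 3 `CCCCc1ccc(-c2cc3cn([C@H]4C[C@H](O)[C@@H](CO)O4)c(=O)nc3o2)nc1` gives > 50000 nM, which is a limit of the assay.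

Compound 3 and compound 1 differ by methyl in place of hydrogen on a saturated chain carbon, four bonds along the chain from an aromatic carbon. The step that the two limits leave unreadable from compound 3 to compound 1 is hemmed in by the limit of > 50000 nM in this assay, at which 3 of the 3 values shown sit, so its size cannot be read. The cores of compound 2 and compound 3 differ in more than one place; that difference is not broken down here.

Compound 4 `CCCCCCc1cnc(-c2cc3cn([C@H]4C[C@H](O)[C@@H](CO)O4)c(=O)nc3o2)nc1` is not yet measured. It differs from compound 2 by methyl in place of hydrogen on a saturated chain carbon, five bonds along the chain from an aromatic carbon. This is the same kind of change as from compound 3 to compound 1, the added methyl here sitting five bonds rather than four bonds along the chain from an aromatic carbon. Because compound 2 gives > 50000 nM in this assay, the expected step that the limit leaves unreadable from compound 2 to compound 4 is taken as small, with all three shown values at the limit of > 50000 nM in this assay, at which 3 of the 3 values shown sit. Compound 4 is therefore expected near 60000 nM in this assay, most likely reported again only as a limit.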

Compound 4, half-maximal cytotoxic concentration: > 50000 nM
Compound 4 ended at the assay's limit; the forecaster's own chance of this, stated with the estimate: 85%; the middle value does not contradict the limit.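

The step from compound 2 to compound 4 cannot be read in this assay because both values are limits: the limit of > 50000 nM in this assay, at which 4 of the 4 values shown sit.

The compounds shown leave open at what concentration any of them turns cytotoxic, and whether chain length alters it.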